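This account rests on a few compounds, and the source may have more. Where it says the series, first, only, none or still open, it means among the compounds named here.

Of the compounds shown here, three built on one shared core have been tested in an ADME assay on NIH3T3 cells (Mus musculus) for cytotoxicity, read by MTT assay, with a stated time of 24 h; on this read-out lower numbers stand for stronger inhibition and higher numbers for weaker inhibition. Compound 1 `O=C(CSc1nnc(-c2ccncc2)o1)N/N=C/c1ccccc1` gives 167000 nM. Compound 2 `O=C(CSc1nnc(-c2ccncc2)o1)N/N=C/c1ccc(Cl)cc1` differs from compound 1 by chloro in place of hydrogen on an aromatic carbon; in this assay compound 2 gives 181000 nM, and that step is a 1.1-fold higher number from compound 1 to compound 2 (0.03 log units; within the scatter). Compound 3 `O=C(CSc1nnc(-c2ccncc2)o1)N/N=C/c1ccccc1O` differs from compound 1 by hydroxy in place of hydrogen on an aromatic carbon, and in this assay compound 3 gives 155000 nM. The related steps are a 1.1-fold lower number from compound 1 to compound 3 (0.03 log units; within the scatter) and a 1.2-fold lower number from compound 2 to compound 3 (0.07 log units; within the scatter), so none of the three can be set apart from the others on this read-out.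

Compound 4 `O=C(CSc1nnc(-c2ccncc2)o1)N/N=C/c1cc(Cl)ccc1O` awaits measurement in this assay. It differs from compound 3 by chloro in place of hydrogen on an aromatic carbon. The same change, chloro in place of hydrogen on an aromatic carbon, was also made between compound 1 and compound 2, where it gave a 1.1-fold higher number from compound 1 to compound 2 (0.03 log units; within the scatter). The surroundings are not identical: in compound 2 the chloro sits para to a large group, while in compound 4 it sits meta to a large group and para to a hydroxy group, so this is the same kind of change rather than the same change. The two cores differ by hydroxy in place of hydrogen on an aromatic carbon.

The expected step is a 1.0-fold higher number from compound 3 to compound 4 (0.01 log units; within the scatter), resting on the earlier step of this kind, which was a 1.1-fold higher number from compound 1 to compound 2 (0.03 log units; within the scatter). Compound 4 is therefore estimated at 160000 nM, with a range from 90000 nM to 300000 nM.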

Compound 4, half-maximal inhibitory concentration: 166000 nM
Compound 4: middle estimate off by 1.0-fold (0.02 log units), on the low side; measured number inside the range.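

The new step is a 1.1-fold higher number from compound 3 to compound 4 (0.03 log units; within the scatter), and the other two new steps, a 1.1-fold lower number from compound 2 to compound 4 (0.04 log units; within the scatter) and a 1.0-fold lower number from compound 1 to compound 4 (0.00 log units; within the scatter), are just as small, so the four compounds cannot be told apart in this assay. Set beside the earlier chloro step, the new one agrees with it: the same change on two cores in this assay, a 1.1-fold higher number (0.03 log units; within the scatter) from compound 1 to compound 2 and a 1.1-fold higher number (0.03 log units; within the scatter) from compound 3 to compound 4, 1.0-fold (0.01 log units) apart, within the scatter of two such steps. The chloro step therefore stays within the scatter both on the core with the hydroxy group and on the core without it, but this shows only that no effect can be seen on either core; it does not show that an effect of any definite size carries from one core to the other, or that chloro would behave the same way elsewhere on the ring.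

From the compounds shown here alone, only chloro and hydroxy appear as substituents on this aromatic ring, so it remains open whether an amine, a carboxylic acid or a longer chain such as a butoxy group there would give a step beyond the scatter. Also open, going by these compounds, is whether any such step would carry across cores, and how a change to the shared core itself would read in this assay.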